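Notes on the step from compound 2 to compound 4

The source may report more compounds than this note shows. Statements on the series, on what has been measured and on what is new or still open speak of the compounds shown alone.

Measured in an assay on isolated protein for inhibition of Myeloperoxidase (Homo sapiens), with a stated time of 10 min; on this read-out higher numbers stand for weaker inhibition and lower numbers for stronger inhibition:
compound 1 `Nc1cc(Cc2ccn(-c3cccc(-c4ccccc4)c3)n2)c2nn[nH]c2n1`: 85 nM
compound 2 `Nc1cc(Cc2ccn(Cc3cccc(-c4ccccc4)c3)n2)c2nn[nH]c2n1`: 55 nM
compound 3 `Nc1cc(C2CCNCc3cccc(c3)Oc3cccc(c3)Cn3cc2cn3)c2nn[nH]c2n1`: 36 nM

The three measured compounds share a core and differ in how the pyrazole is linked and substituted. In this assay the number for compound 2 sits between those of compound 1 and compound 3, and both gaps lie within the usual scatter, so no order among the three is claimed and none of them is called the most or least potent. Among the measured compounds shown here, no step between measured compounds that differ in one place is available, so the measured set gives no guide to how a single change moves the number.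

Compound 4 `Nc1cc(Cc2ccn(Cc3cccc(C4CCNCC4)c3)n2)c2nn[nH]c2n1` has not yet been measured. Against compound 2 the difference is piperidin-4-yl in place of phenyl on an aromatic carbon. The measured compounds carry no comparable change, and their numbers do not separate beyond the scatter, so there is no basis for expecting a step in either direction. The step from compound 2 to compound 4 in this assay is expected to be a 1.3-fold higher number from compound 2 to compound 4 (0.10 log units; within the scatter), that is, none beyond the scatter. Compound 4 is estimated at 70 nM in this assay, with a range from 25 nM to 200 nM.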

Compound 4, half-maximal inhibitory concentration: 100 nM
Compound 4: the middle estimate sits 1.4-fold (0.15 log units) below what was measured; measured number inside the range.
By their numbers in this assay, from the lowest: compounds 3, 2, 1 and 4 (each within the scatter of the next, the first and the last beyond it).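

In this assay, piperidin-4-yl in place of phenyl on this aromatic carbon, meta to a large group, gives a 1.8-fold higher number from compound 2 to compound 4 (0.26 log units; within the scatter). Among the compounds shown here, this is the first single-place comparison, and it shows that the number at this position stays within the scatter when a six-membered aromatic ring of carbon only gives way to a six-membered non-aromatic ring with a hetero atom, even though the entering group brings a hydrogen-bond donor and acceptor that phenyl lacks. Nothing at hand bears on why the number holds across this change.

One swap at one position cannot show whether the ring itself, its nitrogen or simply the presence of a six-membered substituent carries the result, and the compounds shown do not separate these. Also open, on these data alone, is how the number would respond to other groups on this carbon, such as a morpholine ring, an open-chain amine, a carboxylic acid or a longer chain, and whether a substituent on the piperidine nitrogen would move it beyond the scatter.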